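The source may report more compounds than this note shows. Statements on the series, on what has been measured and on what is new or still open speak of the compounds shown alone.

For the measured compounds named here, compound 2 `O=C(CCCCC(S)CCS)NO` gives the higher of the two numbers so far in a functional assay on KB cells (Homo sapiens) for inhibition, read by MTT assay, with a stated time of 24 h, tested at 10 ug/mL (a lower number here means less inhibition of growth, a higher number more inhibition of growth at the concentration tested), at 41.5%. Going by the values given here, compound 1 `O=C(CCCCC1CCSS1)NO` gives 0.89% in this assay, a number far below compound 2 and beyond the scatter; no single step joins these two, so only their two values stand side by side. Compound 3 `O=C(CCCCC(S)CCS)Nc1ccccn1` is not yet measured; it differs from compound 2 by pyridin-2-yl in place of hydroxy on an amide-type nitrogen. Among the compounds with values here, with no measured step to lean on, a downward step is expected, beyond the scatter, a number 26.5 percentage points lower from compound 2 to compound 3 (beyond the scatter). Compound 3 is estimated at 15%, within 0% to 40%.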

Compound 3, percent growth inhibition at one concentration: 0.28%
Compound 3: the middle estimate sits 14.7 percentage points above what was measured; measured number inside the range.
By their numbers in this assay, from the lowest: compounds 3 and 1 (each within the scatter of the next); then compound 2.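

With the open dithiol chain held constant, pyridin-2-yl in place of hydroxy on the amide-type nitrogen gives a number 41.2 percentage points lower from compound 2 to compound 3 (beyond the scatter) in this assay. The growth inhibition at this concentration therefore depends strongly on what sits at this position, and the open dithiol chain kept in compound 3 is not enough to retain it. Nothing available explains the size of this step.

Going by these compounds, whether methoxy, an amine or a plain phenyl ring on this nitrogen would retain any inhibition remains open. The effect of a longer chain with hydroxy kept in place is also unknown.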